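Replacing the proline acid with a serine-like acid

The source may report more compounds than this note shows. Statements on the series, on what has been measured and on what is new or still open speak of the compounds shown alone.

Measured compounds:
compound 1 `O=C(O)[C@@H]1CCCN1C(=O)CN(c1nc(Cl)nc2[nH]cnc12)C1CC1` gives 31.5%
compound 2 `O=C(OCc1ccccc1)[C@@H]1CCCN1C(=O)CN(c1nc(Cl)nc2[nH]cnc12)C1CC1` gives 33.2%
compound 3 `O=C(CN(c1nc(Cl)nc2[nH]cnc12)C1CC1)N[C@@H](CC(=O)OCc1ccccc1)C(=O)OCc1ccccc1` gives 34.7%

In a functional assay on the whole organism (Tail, strain ICR) with Mus musculus as the target, in the tail flick test, with a stated time of 30 min, at a dose of 25 umol/kg by the oral route (a higher number here means a stronger effect of the compound at the dose given, a lower number a weaker effect), compound 1 stands within the scatter of both other compounds: the step of a number 1.7 percentage points higher from compound 1 to compound 2 (within the scatter) lies within it, and the value of compound 3 differs from that of compound 1 by no more than the scatter. Compound 4 `O=C(CN(c1nc(Cl)nc2[nH]cnc12)C1CC1)N[C@@H](CO)C(=O)O` carries (1-carboxy-2-hydroxyethyl)amino in place of 2-carboxypyrrolidin-1-yl on a carbonyl carbon. No measured step changes this part of the molecule, so nothing shown bears directly on it; the three values only show that changes at the acid end, such as the benzyl ester, have not moved the read-out beyond the scatter. Compound 4 is therefore expected to sit close to compound 1, with a step of a number 0.5 percentage points higher from compound 1 to compound 4 (within the scatter) not beyond the scatter. The estimate for compound 4 is 32%, between 20% and 45%.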

Compound 4, a percentage reported as activity, at one dose (the size of the read-out at that dose, not a potency): 38.7%
For compound 4 the middle estimate is 6.7 percentage points below the measured one; the range from low to high includes it.
By their numbers in this assay, from the lowest: compounds 1, 2, 3 and 4 (each within the scatter of the next).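

In this assay, the ring-free (1-carboxy-2-hydroxyethyl)amino in place of 2-carboxypyrrolidin-1-yl on a carbonyl carbon gives a number 7.2 percentage points higher from compound 1 to compound 4 (within the scatter). Among these compounds, this is the first look at a change of this group, and it shows that the ring can be lost without the read-out leaving the scatter. No supporting data bear on what lies behind this result. Still open, from the compounds shown here alone, is whether a simple amine or a longer alkyl chain on this carbonyl carbon would give a read-out beyond the scatter.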